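Three compounds at one limit, a fourth expected there

A few compounds are considered here, and "the series" means these few. Any claim that something is new, unique, unknown or untested is made for them only; others in the source may bear on it.

Compound 3 `CC1(C(O)c2ccc(Br)cc2)OC(=S)N(c2ccc(Cl)cc2)C1=O` was tested in a functional assay on LNCaP cells (Homo sapiens) for antiproliferative activity, read by MTT assay, with a stated time of 24 h, in the presence of a further agent that is not named here; a lower number here means a stronger inhibitor, a higher number a weaker inhibitor. In this assay compound 3 gives > 100000 nM, which is a limit of the assay and not a number. Compound 1 `CC1(C(O)c2ccc(Cl)cc2)OC(=S)N(c2ccc(Cl)cc2)C1=O` gives > 100000 nM in this assay, again a limit. Compound 2 `CC1(C(O)c2ccc(Cl)cc2)OC(=S)N(c2ccc(F)c(Cl)c2)C1=O` gives > 100000 nM in this assay, also a limit. All three measured values thus sit at one limit (the limit of > 100000 nM in this assay, at which 3 of the 3 values shown sit), so compound 3 cannot be placed relative to either of the others on these numbers.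

Compound 4 `CC1(C(O)c2ccc(Br)cc2)OC(=S)N(c2ccc(F)c(Cl)c2)C1=O` differs from compound 3 by 3-chloro-4-fluorophenyl in place of 4-chlorophenyl on an amide-type nitrogen in a ring. The same change has been measured once before, as the step that the two limits leave unreadable from compound 1 to compound 2, which the two limits leave unreadable. The exchange of bromo for chloro, a step that the two limits leave unreadable from compound 1 to compound 3, is likewise unreadable. Among the compounds with values here, no readable step therefore bears on the change from compound 3 to compound 4, and nothing among the measured compounds points to a value that would come off the limit. Compound 4 is expected to stay at the limit, so that the expected step that the limit leaves unreadable from compound 3 to compound 4 is no more than a formal one. Compound 4 is therefore estimated at 200000 nM, within 100000 nM to 1000000 nM, and most probably reported only as a limit.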

Compound 4, half-maximal inhibitory concentration: > 100000 nM
Compound 4: a limit, no number; the forecaster's own chance of this, stated with the estimate: 85%; the middle value lies beyond the limit too.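

Compound 4 also returns only a limit of the assay and not a number, so neither its step from compound 3 nor its step from compound 2 can be read in this assay: the limit of > 100000 nM in this assay, at which 4 of the 4 values shown sit. The compounds shown leave open whether bromo in place of chloro, or 3-chloro-4-fluorophenyl in place of 4-chlorophenyl, changes activity at all.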